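Aminopyridinyl azetidine ureas: amide-tail exchange on the second core

The source may hold more compounds than are shown below. What is called first, only, known or untested is meant among the compounds shown, and "the series" means these compounds.

Measured so far:
compound 1, `C[C@H](NC(=O)[C@@H]1CCCN1C)c1ccc(NC(=O)N2CC(c3ccc(N)nc3)C2)cc1`, 11 nM
compound 2, `CCC(=O)N[C@@H](C)c1ccc(NC(=O)N2CC(c3ccc(N)nc3)C2)cc1`, 58 nM
compound 3, `C[C@H](NC(=O)[C@@H]1CCCN1C)c1ccc(NC(=O)N2CC(c3cncc(N)c3)C2)cc1`, 34 nM

All values come from a functional assay on A2780 cells (Homo sapiens) for antiproliferative activity, read by CellTiter-Glo, with a stated time of 72 h; a higher number here means a weaker inhibitor, a lower number a stronger inhibitor. Compound 1 gives 11 nM, the lowest number of the three. Compound 2 gives 58 nM and compound 3 gives 34 nM; these two lie within the scatter of each other.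

Two changes are seen. The first, (ethyl in place of 1-methylpyrrolidin-2-yl on a carbonyl carbon), gives a 5.3-fold higher number from compound 1 to compound 2 (0.72 log units; beyond the scatter). The second alters the core: 5-aminopyridin-3-yl in place of 6-aminopyridin-3-yl on a saturated ring carbon, giving a 3.1-fold higher number from compound 1 to compound 3 (0.49 log units; beyond the scatter).

Compound 4, `CCC(=O)N[C@@H](C)c1ccc(NC(=O)N2CC(c3cncc(N)c3)C2)cc1`, is not yet measured. It carries the same change relative to compound 3 that compound 2 carries relative to compound 1: ethyl in place of 1-methylpyrrolidin-2-yl on a carbonyl carbon. The place is described in the same words for both pairs, so the change is taken as the same, made on the core of compound 3 rather than that of compound 1.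

On the expectation that the step repeats on the second core, compound 4 is estimated at 170 nM (from 70 nM to 400 nM), an expected step of a 5.0-fold higher number from compound 3 to compound 4 (0.70 log units; beyond the scatter) in this assay, resting on the step of a 5.3-fold higher number from compound 1 to compound 2 (0.72 log units; beyond the scatter) applied to compound 3 at 34 nM.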

Compound 4, half-maximal inhibitory concentration: 770 nM
Estimate against measurement, compound 4: 4.5-fold (0.66 log units) below; the measured number lies above the stated range.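

In this assay ethyl in place of 1-methylpyrrolidin-2-yl gives a 23-fold higher number from compound 3 to compound 4 (1.36 log units; beyond the scatter) and so keeps its direction but not its size from one core to the other: the same change on two cores in this assay, a 5.3-fold higher number (0.72 log units; beyond the scatter) from compound 1 to compound 2 and a 23-fold higher number (1.36 log units; beyond the scatter) from compound 3 to compound 4, 4.3-fold (0.63 log units) apart, beyond the scatter of two such steps
5-aminopyridin-3-yl in place of 6-aminopyridin-3-yl gives a 13-fold higher number from compound 2 to compound 4 (1.12 log units; beyond the scatter) and likewise keeps its direction but not its size when the amide tail differs: the same change on two cores in this assay, a 3.1-fold higher number (0.49 log units; beyond the scatter) from compound 1 to compound 3 and a 13-fold higher number (1.12 log units; beyond the scatter) from compound 2 to compound 4, 4.3-fold (0.63 log units) apart, beyond the scatter of two such steps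
In these four compounds, then, the two changes do not add up independently, so the size of a step on one core is a poor guide to its size on the other; this single set does not show what causes the gap or whether it extends to other amide tails.

Still open, on these data alone, is which feature of the 1-methylpyrrolidin-2-yl group carries the dependence on the core. A dimethylaminomethyl group or a longer chain such as butyl on the same carbonyl carbon, each paired with both aminopyridines, would separate the amine from the chain length.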